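Ring size on the sulfonyl side chain

A few compounds are considered here, and "the series" means these few. Any claim that something is new, unique, unknown or untested is made for them only; others in the source may bear on it.

In a functional assay, read by fluorescence and spectrophotometry, with a stated time of 1 h (on this read-out higher numbers stand for an effect only at larger amounts of compound and lower numbers for an effect already at smaller amounts), compound 2 `O=S(=O)(/C=C/c1ccc(O)c(O)c1)CCC1CCCC1` gives 6800 nM, and compound 1 `CCCCCCS(=O)(=O)/C=C/c1ccc(O)c(O)c1` gives 7300 nM; the two stand together, since the step of a 1.1-fold lower number from compound 1 to compound 2 (0.03 log units; within the scatter) is within the scatter. Compound 3 `O=S(=O)(/C=C/c1ccc(O)c(O)c1)CCCC1CCCCC1` differs from compound 2 by cyclohexylmethyl in place of cyclopentyl on a saturated chain carbon, two bonds along the chain from a sulfonyl sulfur. For the measured compounds named here, the only measured step that bears on this place is a 1.1-fold lower number from compound 1 to compound 2 (0.03 log units; within the scatter), which gave no change beyond the scatter, so no step beyond the scatter is expected in this assay here either. Compound 3 is therefore expected to give 6500 nM, in a range from 2500 nM to 17000 nM. The expected step of a 1.0-fold lower number from compound 2 to compound 3 (0.02 log units; within the scatter) stays within the scatter.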

Compound 3, half-maximal effective concentration: 7900 nM
Compound 3: middle estimate off by 1.2-fold (0.08 log units), on the low side; measured number inside the range.
By their numbers in this assay, from the lowest: compounds 2, 1 and 3 (each within the scatter of the next).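

In this assay the sulfonyl side chain accepts a six-membered ring as readily as a five-membered one: the step of a 1.2-fold higher number from compound 2 to compound 3 (0.07 log units; within the scatter) comes with cyclohexylmethyl in place of cyclopentyl, and the step of a 1.1-fold higher number from compound 1 to compound 3 (0.03 log units; within the scatter) with cyclohexyl in place of propyl. Both changes stay within the scatter, so compound 1, compound 2 and compound 3 stand level, whether the chain ends in a ring or not. No measurement on hand offers a reason for this.

Still open, going by these compounds, is whether an amine or a carboxylic acid at the chain end would move the number. On these data alone, a phenyl ring or a longer chain at this place is equally open.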